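Sulfanyl to cyanoamino on the shared core

The source may report more compounds than this note shows. Statements on the series, on what has been measured and on what is new or still open speak of the compounds shown alone.

Measured so far:
compound 1 `CC(C)(C)c1cc(/C=C/c2nnc(S)s2)cc(C(C)(C)C)c1O` gives 1800 nM in an assay on RBL-1 cells for inhibition of Polyunsaturated fatty acid 5-lipoxygenase (Rattus norvegicus); on this read-out lower numbers stand for stronger inhibition and higher numbers for weaker inhibition
compound 2 `CC(C)(C)c1cc(Sc2nnc(S)s2)cc(C(C)(C)C)c1O` gives 1100 nM in this assay

Compound 2 holds the lowest of the two numbers, but its gap to compound 1 lies within the usual scatter, so the two measured compounds read as alike on this read-out and no order between them is claimed.

Compound 3 `CC(C)(C)c1cc(Sc2nnc(NC#N)s2)cc(C(C)(C)C)c1O` is not yet measured. It differs from compound 2 in one place: cyanoamino in place of sulfanyl on an aromatic carbon. For the measured compounds named here, no step between two measured compounds shows what this change does, so any expectation rests on the two measured numbers alone and on the change itself.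

The step of a 1.4-fold higher number from compound 2 to compound 3 (0.13 log units; within the scatter) is expected to stay within the scatter, with no direction that can be trusted. For compound 3 the estimate in this assay is 1500 nM, expected to fall between 500 nM and 5000 nM.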

Compound 3, half-maximal inhibitory concentration: 3100 nM
Compound 3: the middle estimate sits 2.1-fold (0.32 log units) below what was measured; the range from low to high includes it.
By their numbers in this assay, from the lowest: compounds 2, 1 and 3 (each within the scatter of the next, the first and the last beyond it).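

In this assay, for the compounds shown here, cyanoamino in place of sulfanyl on an aromatic carbon gives a 2.8-fold higher number from compound 2 to compound 3 (0.45 log units; beyond the scatter) and is the first change to read beyond the scatter. This position on the five-membered aromatic ring therefore responds to substitution, and here the change goes toward weaker inhibition. The step is modest, so sulfanyl is not essential for measurable inhibition, as compound 3 still gives 3100 nM in this read-out. No available evidence bears on the reason for this step.

From the compounds shown here alone, a single exchange at this position sets no trend, and it remains open whether a plain amine, a carboxylic acid or a methyl group there would fall closer to sulfanyl or to cyanoamino. Also open, going by these compounds, is whether the same exchange gives a similar step on the core of compound 1.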